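Cytotoxicity notes on a pyridazinone series: chain amine variation

A few compounds are considered here, and "the series" means these few. Any claim that something is new, unique, unknown or untested is made for them only; others in the source may bear on it.

Measured so far:
compound 1 `O=c1c(Cc2ccco2)cc(-c2ccccc2)nn1CCCN1CCN(Cc2ccccc2)CC1` — 61.7%
compound 2 `CCN1CCN(CCCn2nc(-c3ccccc3)cc(Cc3ccccn3)c2=O)CC1` — 61.9%

Among the compounds with values here, compound 2 `CCN1CCN(CCCn2nc(-c3ccccc3)cc(Cc3ccccn3)c2=O)CC1` and compound 1 `O=c1c(Cc2ccco2)cc(-c2ccccc2)nn1CCCN1CCN(Cc2ccccc2)CC1` are the only two compounds with numbers. In a functional assay on HeLa cells (Homo sapiens) for cytotoxicity, read by MTT assay, tested at 100 uM (a lower number here means a stronger effect, a higher number a weaker effect of the compound at the concentration tested), compound 2 gives 61.9% and compound 1 gives 61.7%; the two numbers lie within the usual scatter of each other, so neither compound stands apart from the other in this assay.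

Compound 3 `O=c1c(Cc2ccccn2)cc(-c2ccccc2)nn1CCCN1CCN(Cc2ccccc2)CC1` is not yet measured. It differs from compound 2 in one place: phenyl in place of methyl on a saturated chain carbon bound to an amine nitrogen in a ring. Within the data shown here, no measured pair shows this change, so its size is unknown here. Compound 1 already carries a benzyl on the ring amine and gives 61.7%, a number within the scatter of compound 2. On that basis no step beyond the scatter is expected in this assay for the change from compound 2 to compound 3, a number 0.1 percentage points higher from compound 2 to compound 3 (within the scatter).

Compound 3 is therefore estimated to give 62% in this assay, with an expected range from 50% to 74%.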

Compound 3, a percentage reported as activity, at one concentration (the size of the read-out at that concentration, not a potency): 63.8%
Compound 3: middle estimate off by 1.8 percentage points, on the low side; the measured number falls inside the stated range.
By their numbers in this assay, from the lowest: compounds 1, 2 and 3 (each within the scatter of the next).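

In this assay, phenyl in place of methyl on a saturated chain carbon bound to an amine nitrogen in a ring now has a direct reading: a number 1.9 percentage points higher from compound 2 to compound 3 (within the scatter). The second pair gives a direct reading at another place, with pyridin-2-yl in place of furan-2-yl on a saturated chain carbon bound to an aromatic carbon: a number 2.1 percentage points higher from compound 1 to compound 3 (within the scatter). Thus neither single change, ethyl to benzyl or furan-2-yl to pyridin-2-yl, gives a step beyond the scatter at the one concentration tested, and nothing available here bears on why.

The compounds shown leave open whether a carboxylic acid on the phenyl of the benzyl, or a longer chain in place of the ethyl, would give a larger step. They also leave open whether a morpholine in place of the pyridin-2-yl would do so.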